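This account rests on a few compounds, and the source may have more. Where it says the series, first, only, none or still open, it means among the compounds named here.

Compound 1 `CC(C)S(=O)(=O)n1c(N)nc2ccc(NC(=O)c3ccccc3)cc21` is the reference point of the series. In an ADME assay on HepG2 2.2.15 cells (Homo sapiens) for cytotoxicity, read by MTT assay, with a stated time of 6 h (on this read-out lower numbers stand for higher toxicity in this test and higher numbers for lower toxicity in this test), compound 1 gives only a limit of the assay, > 500000 nM. Compound 2 `Cc1ccc(C(=O)Nc2ccc3nc(N)n(S(=O)(=O)C(C)C)c3c2)cc1` likewise reaches only a limit in this assay, > 500000 nM. The step that the two limits leave unreadable from compound 1 to compound 2 therefore cannot be sized, as both values sit at the limit of > 500000 nM in this assay, at which 2 of the 2 values shown sit. Compound 3 `CC(C)S(=O)(=O)n1c(N)nc2ccc(NCc3ccccc3)cc21` differs from compound 1 by benzyl in place of benzoyl on a nitrogen on an aromatic ring. Going by the values given here, no measured step covers this change, and the single measured step is unreadable, so no direction follows from it. Compound 3 is expected to give 500000 nM, range 100000 nM to 2000000 nM. The step of a number no higher from compound 1 to compound 3 (the limit leaves the size open) is thus estimated to remain within scatter.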

Compound 3, half-maximal cytotoxic concentration: 98000 nM
For compound 3 the middle estimate is 5.1-fold (0.71 log units) above the measured one; the measured number lies below the stated range.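

In this assay, going by these compounds alone, the change at this nitrogen gives an at least 5.1-fold lower number from compound 1 to compound 3 (0.70 log units; beyond the scatter) and so yields the first readable step, while the step from compound 1 to compound 2 cannot be read. The amide carbonyl at this place therefore matters to the read-out, whereas the aromatic methyl remains uninformative. Going by these compounds, the full size of the step stays open, since its starting point is a limit: the limit of > 500000 nM in this assay, at which 2 of the 3 values shown sit.

On these data alone, whether a phenethyl chain or a sulfonyl link at this nitrogen would lower the number further remains open. As far as these compounds go, whether the ring of the benzyl group contributes to the step also remains open.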